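A few compounds are considered here, and "the series" means these few. Any claim that something is new, unique, unknown or untested is made for them only; others in the source may bear on it.

Measured in an ADME assay on BHK-21 cells (Mesocricetus auratus) for cytotoxicity, read by MTT assay, with a stated time of 72 h; a higher number here means that more compound is tolerated, a lower number that less compound is tolerated:
Compound 1 `Cc1ccc(-c2nn(-c3ccccc3)cc2CNc2ccc(Br)cc2)cc1`: > 100000 nM (a limit)
Compound 2 `FC(F)(F)c1ccc(NCc2cn(-c3ccccc3)nc2-c2ccc(Cl)cc2)cc1`: 17000 nM

Among the compounds with values here, compound 2, at 17000 nM, holds the only actual number in this assay. Compound 3 `Cc1ccc(-c2nn(-c3ccccc3)cc2CNc2ccc(C(F)(F)F)cc2)cc1` differs from compound 2 as follows: methyl in place of chloro on an aromatic carbon. This is methyl in place of chloro on an aromatic carbon, or 4-chlorophenyl to 4-methylphenyl. Within the data shown here, no measured step isolates this change. Compound 1 also carries 4-methylphenyl, and its > 100000 nM is a limit. A modest rise, slightly beyond the scatter, is therefore expected: a 2.4-fold higher number from compound 2 to compound 3 (0.37 log units; beyond the scatter). For compound 3 the estimated value is 40000 nM, with an expected range of 15000 nM to 100000 nM.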

Compound 3, half-maximal cytotoxic concentration: 88000 nM
Estimate against measurement, compound 3: 2.2-fold (0.34 log units) below; low and high end bracket the measured number.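

In this assay, methyl in place of chloro on this aromatic carbon now has a measured size: a 5.2-fold higher number from compound 2 to compound 3 (0.71 log units; beyond the scatter), so more compound is tolerated with 4-methylphenyl than with 4-chlorophenyl in this pair. Trifluoromethyl in place of bromo gives an at least 1.1-fold lower number from compound 1 to compound 3 (0.05 log units; that floor lies within the scatter). That step starts from a limit held by compound 1, and its floor does not separate the two groups: the limit of > 100000 nM in this assay, at which 1 of the 3 values shown sits.

Open, as far as these compounds go, is whether methoxy, an amine or a carboxylic acid on this aromatic carbon would keep the number as high as in compound 3. Also open, from the compounds shown here alone, is whether the chloro to methyl step holds when bromo replaces trifluoromethyl.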